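The source may report more compounds than this note shows. Statements on the series, on what has been measured and on what is new or still open speak of the compounds shown alone.

Measured so far in a functional assay on MX1 cells (Homo sapiens) for inhibition, read by MTT assay, with a stated time of 120 h; a higher number here means a weaker inhibitor, a lower number a stronger inhibitor:
Compound 1 `CNC(=O)/C=C/c1ccc(NC(=O)Nc2ccc(Cl)c(C(F)(F)F)c2)cc1` gives 13800 nM.
Compound 2 `CNC(=O)/C(C)=C/c1ccc(NC(=O)Nc2ccc(Cl)c(C(F)(F)F)c2)cc1` gives only a limit of the assay, > 50000 nM.
Compound 3 `CC1CN(C(=O)/C=C/c2ccc(NC(=O)Nc3ccc(Cl)c(C(F)(F)F)c3)cc2)CC(C)O1` gives 12800 nM.

Compound 2 differs from compound 1 by 2-(methylcarbamoyl)prop-1-en-1-yl in place of 2-(methylcarbamoyl)ethenyl on an aromatic carbon. That step reads an at least 3.6-fold higher number from compound 1 to compound 2 (0.55 log units; beyond the scatter), and compound 2 sits at the limit of > 50000 nM in this assay, at which 1 of the 3 values shown sits, so its true value is not pinned down. Compound 3 differs from compound 1 by 2,6-dimethylmorpholin-4-yl in place of methylamino on a carbonyl carbon; the step is a 1.1-fold lower number from compound 1 to compound 3 (0.03 log units; within the scatter), so the two compounds are indistinguishable in this assay.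

Compound 4 `C/C(=C\c1ccc(NC(=O)Nc2ccc(Cl)c(C(F)(F)F)c2)cc1)C(=O)N1CC(C)OC(C)C1` is not yet measured. It differs from compound 2 by 2,6-dimethylmorpholin-4-yl in place of methylamino on a carbonyl carbon, the same change at the same place as between compound 1 and compound 3. The expected step is a step that the limit leaves unreadable from compound 2 to compound 4, because a 1.1-fold lower number from compound 1 to compound 3 (0.03 log units; within the scatter) was within the scatter, and the change is made on a compound that already sits at the limit. Compound 4 is therefore expected to return another limit rather than a number, with an estimate of 60000 nM, from 25000 nM to 150000 nM.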

Compound 4, half-maximal inhibitory concentration: > 50000 nM
Compound 4: no number, only a limit (the forecaster's own chance of this, stated with the estimate: 75%); the middle value does not contradict the limit.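

No new step can be read between compound 2 and compound 4 in this assay, because both return only a limit and no number: the limit of > 50000 nM in this assay, at which 2 of the 4 values shown sit.

The compounds shown leave open the true values of compound 2 and compound 4, and so whether 2,6-dimethylmorpholin-4-yl in place of methylamino on this carbonyl carbon changes the reading at all.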